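A few compounds are considered here, and "the series" means these few. Any claim that something is new, unique, unknown or untested is made for them only; others in the source may bear on it.

Working notes on the series, a functional assay on NCI-H460 cells (Homo sapiens) for antiproliferative activity, read by trypan blue exclusion, with a stated time of 24 h; on this read-out lower numbers stand for stronger inhibition and higher numbers for weaker inhibition.

Compound 1 `O=C1NC(=O)/C(=C/c2cn(Cc3ccccc3)c3ccccc23)N1` carries the unsubstituted ring on its pendant group and gives 14200 nM in this assay. Compound 2 `N#Cc1ccc(Cn2cc(/C=C3\NC(=O)NC3=O)c3ccccc32)cc1`, which differs by cyano in place of hydrogen on an aromatic carbon, gives 19100 nM; the step of a 1.3-fold higher number from compound 1 to compound 2 (0.13 log units; within the scatter) stays within the scatter. Compound 3 `O=C1NC(=O)/C(=C/c2cn(Cc3ccc([N+](=O)[O-])cc3)c3ccccc23)N1` carries nitro in place of hydrogen on the same aromatic carbon. For compound 3 this assay reports only a limit, > 40000 nM, at the limit of > 40000 nM in this assay, at which 1 of the 3 values shown sits. The step of an at least 2.8-fold higher number from compound 1 to compound 3 (0.44 log units; beyond the scatter) and the step of an at least 2.0-fold higher number from compound 2 to compound 3 (0.32 log units; beyond the scatter) therefore both run toward weaker inhibition, each beyond the scatter, and compound 3 is the weakest of the three measured compounds on the numbers shown.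

Compound 4 `COC(=O)c1ccc(Cn2cc(/C=C3\NC(=O)NC3=O)c3ccccc32)cc1` is not yet measured. It differs from compound 3 by methoxycarbonyl in place of nitro on an aromatic carbon. Among the measured compounds shown here, no measured step replaces nitro with methoxycarbonyl, so the two steps into compound 3 are the only ones that bear on it: both show that nitro at this place sits beyond the scatter toward weaker inhibition relative to hydrogen and to cyano. Removing nitro is therefore expected to move the number back toward the range of compound 1 and compound 2, and a step of an at least 1.6-fold lower number from compound 3 to compound 4 (0.20 log units; that floor lies within the scatter) toward stronger inhibition is expected in this assay. For compound 4 the estimate in this assay is 25000 nM, within 10000 nM to 60000 nM.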

Compound 4, half-maximal inhibitory concentration: 30800 nM
Beside the measured number, compound 4's estimate is 1.2-fold (0.09 log units) below it; measured number inside the range.
By their numbers in this assay, from the lowest: compounds 1, 2 and 4 (each within the scatter of the next, the first and the last beyond it). At a limit, above all of these: compound 3.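

In this assay, methoxycarbonyl gives a measured step away from hydrogen at this place, on an aromatic carbon para to a large group: a 2.2-fold higher number from compound 1 to compound 4 (0.34 log units; beyond the scatter), which lies beyond the scatter and runs toward weaker inhibition, while a 1.6-fold higher number from compound 2 to compound 4 (0.21 log units; within the scatter) stays within the scatter, so methoxycarbonyl and cyano cannot be told apart here. The earlier compounds shown here showed a shift beyond the scatter from hydrogen only against a limit, so the pattern of weaker inhibition on replacing hydrogen now rests on one measured number, with compound 2 going against it. The step of an at least 1.2-fold lower number from compound 3 to compound 4 (0.11 log units; that floor lies within the scatter) has a floor within the scatter and does not order nitro against methoxycarbonyl, and compound 3 remains a limit and not a number: the limit of > 40000 nM in this assay, at which 1 of the 4 values shown sits.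

None of the replacements shown gives a number beyond the scatter below that of compound 1, so whether any group at this place can strengthen inhibition stays open. An amine, a carboxylic acid or a methoxy group at this place would test that, and the compounds shown give no account of what separates hydrogen from methoxycarbonyl here.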